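This account rests on a few compounds, and the source may have more. Where it says the series, first, only, none or still open, it means among the compounds named here.

Compound 1 `CCOC(=O)C12C(=O)OCC=C1COC2c1ccccc1`: 12800 nM
Compound 2 `CCOC(=O)C12C(=O)OCC=C1COC2c1ccc(Br)cc1`: 48700 nM
Compound 3 `CCOC(=O)C12C(=O)OCC=C1COC2c1ccc(OC)cc1`: 18300 nM

In a functional assay on HeLa cells (Homo sapiens) for cytotoxicity, read by MTT assay (on this read-out higher numbers stand for weaker inhibition and lower numbers for stronger inhibition), compound 3 holds the second highest of the three numbers. The nearest step to it, a 1.4-fold higher number from compound 1 to compound 3 (0.16 log units; within the scatter), lies within the scatter, while the furthest, a 2.7-fold lower number from compound 2 to compound 3 (0.43 log units; beyond the scatter), goes beyond it. Within the data shown here, the only step beyond the scatter that starts from compound 1 is a 3.8-fold higher number from compound 1 to compound 2 (0.58 log units; beyond the scatter).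

Compound 4 `CCOC(=O)C12C(=O)OCC=C1COC2c1ccc(OC)c(OC)c1` differs from compound 3 in one place: methoxy in place of hydrogen on an aromatic carbon. The measured step that bears most directly on this change is a 1.4-fold higher number from compound 1 to compound 3 (0.16 log units; within the scatter), where the same kind of group entered in place of hydrogen and the number did not move beyond the scatter. The step of a 2.7-fold lower number from compound 2 to compound 3 (0.43 log units; beyond the scatter) swaps one group for another and is less comparable. A second methoxy is therefore expected to leave the number roughly where compound 3 stands, with at most a slight drift upward, an expected step of a 1.2-fold higher number from compound 3 to compound 4 (0.08 log units; within the scatter). For compound 4 the estimate in this assay is 22000 nM, with a range from 9000 nM to 55000 nM.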

Compound 4, half-maximal inhibitory concentration: 10000 nM
Compound 4: middle estimate off by 2.2-fold (0.34 log units), on the high side; the range from low to high includes it.
By their numbers in this assay, from the lowest: compounds 4, 1 and 3 (each within the scatter of the next); then compound 2.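

In this assay, methoxy in place of hydrogen on an aromatic carbon ortho to a methoxy group and meta to a large group gives a 1.8-fold lower number from compound 3 to compound 4 (0.26 log units; within the scatter). Together with a 1.4-fold higher number from compound 1 to compound 3 (0.16 log units; within the scatter), this shows that each of the two methoxy additions stays within the scatter, so the second methoxy, on a carbon the earlier compounds left bearing hydrogen, adds no change that can be read, and the opposite directions of the two steps carry no meaning. No measurement among those shown offers an explanation for this result.

The compounds shown leave open whether a hydroxyl or an amine on this same carbon would also stay within the scatter. They also leave open whether bromo, which gave a 3.8-fold higher number from compound 1 to compound 2 (0.58 log units; beyond the scatter) at its own position, would produce a step beyond the scatter here.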